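The source may report more compounds than this note shows. Statements on the series, on what has been measured and on what is new or still open speak of the compounds shown alone.

Measured compounds in a functional assay on HeLa cells (Homo sapiens) for inhibition; on this read-out lower numbers stand for stronger inhibition and higher numbers for weaker inhibition:
- compound 1, `Oc1ccc(-c2cc(-c3ccc(F)cc3)cc(-c3ccccc3O)n2)cc1`: > 50000 nM
- compound 2, `Oc1ccc(-c2cc(-c3ccc(F)cc3)cc(-c3cccc(O)c3)n2)cc1`: 8080 nM
- compound 3, `Oc1cccc(-c2cc(-c3ccccc3C(F)(F)F)cc(-c3ccccc3O)n2)c1`: 16800 nM

The value of compound 1 in this assay is a limit, (the limit of > 50000 nM in this assay, at which 1 of the 3 values shown sits), and not a number. Compound 2 differs from compound 1 in one place, (3-hydroxyphenyl in place of 2-hydroxyphenyl on an aromatic carbon), and this change gives an at least 6.1-fold lower number from compound 1 to compound 2 (0.79 log units; beyond the scatter). Compound 3 sits highest of the two numbers shown; its nearest neighbour is compound 2, and the gap between them is beyond the scatter. The difference between the core of compound 1 and the core of compound 3 is not broken down here.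

Compound 4, `Oc1cccc(-c2cc(-c3ccccc3C(F)(F)F)cc(-c3cccc(O)c3)n2)c1`, has not yet been measured in this assay. It differs from compound 3 by 3-hydroxyphenyl in place of 2-hydroxyphenyl on an aromatic carbon. Among the measured compounds shown here, this is the same kind of change as the one from compound 1 to compound 2, but not the same: there the place was meta to a 4-fluorophenyl group and meta to a 4-hydroxyphenyl group, here it is meta to a 2-(trifluoromethyl)phenyl group and meta to a 3-hydroxyphenyl group. For the measured compounds named here, only one measured pair carries this change, and its starting value is a limit, so the size of the earlier step is itself only a bound.

For compound 4 a step of about a 5.6-fold lower number from compound 3 to compound 4 (0.75 log units; beyond the scatter) is expected, resting on the step from compound 1 to compound 2, an at least 6.1-fold lower number from compound 1 to compound 2 (0.79 log units; beyond the scatter). Compound 4 is estimated to give 3000 nM in this assay, with a range from 800 nM to 10000 nM.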

Compound 4, half-maximal inhibitory concentration: 15200 nM
For compound 4 the middle estimate is 5.1-fold (0.70 log units) below the measured one; measured number outside the range, above it.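

In this assay, 3-hydroxyphenyl in place of 2-hydroxyphenyl on the core of compound 3 gives a 1.1-fold lower number from compound 3 to compound 4 (0.04 log units; within the scatter). Set beside the earlier step, this change does not carry from one core to the other at a fixed size: the same change on two cores in this assay, an at least 6.1-fold lower number (0.79 log units; beyond the scatter) from compound 1 to compound 2 and a 1.1-fold lower number (0.04 log units; within the scatter) from compound 3 to compound 4, at least 5.5-fold (0.74 log units) apart, beyond the scatter of two such steps Compound 1 gives > 50000 nM, which is a limit and not a number, so the earlier step is only a bound, and with a single pair on each core the data do not show which difference between the core of compound 1 and the core of compound 3 goes with the gap between the two steps.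

On these data alone, it remains open whether the 2-(trifluoromethyl)phenyl group of compound 3 and compound 4 is the part that goes with the missing step, or whether another part of the core does, and a third core carrying the same change would be needed to tell whether either step is the usual one. Also open is how a methoxy group, an amine or a carboxylic acid in the place of the hydroxyl would read in this assay, since the compounds shown vary only where the hydroxyl sits and which other aryl group is present.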